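Halophenyl exchange from compound 1 to compound 4

The source may report more compounds than this note shows. Statements on the series, on what has been measured and on what is new or still open speak of the compounds shown alone.

In a functional assay on HepG2 cells (Homo sapiens) for antiproliferative activity, read by MTT assay, with a stated time of 72 h (on this read-out higher numbers stand for weaker inhibition and lower numbers for stronger inhibition), compound 1 (`NC1=NC2(CCSCC2)N(OCCCOc2cccc(Cl)c2)C(N)=N1`) gives 90 nM and holds the lowest of the two numbers available in this small set. Compound 2 (`NC1=NC2(CCOCC2)N(OCCCOc2ccc(Cl)c(Cl)c2)C(N)=N1`) gives 380 nM as the higher number, a gap beyond the scatter, although the two differ in more than one place and the gap cannot be assigned to any single change. Compound 3 (`NC1=NC2(CCOCC2)N(OCCCOc2cc(Cl)c(Cl)cc2Cl)C(N)=N1`) stands as "not determined" (no result reported) here and so adds no number.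

Compound 4 (`NC1=NC2(CCSCC2)N(OCCCOc2ccccc2Br)C(N)=N1`) keeps the core of compound 1, and the change is 2-bromophenyl in place of 3-chlorophenyl on an oxygen on a saturated carbon. For the measured compounds named here, no measured pair in the set isolates a change of this kind, so the size of the step cannot be read from the data. Going by the values given here, with compound 1 at 90 nM as the only number on this core, a small rise is expected in this assay rather than a large move in either direction, with a wide margin. The expected step is a 1.7-fold higher number from compound 1 to compound 4 (0.22 log units; within the scatter) in size, within the scatter or close to it. For compound 4 the estimated value is 150 nM with 40 nM to 600 nM as its expected range.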

Compound 4, half-maximal inhibitory concentration: 90 nM
Compound 4: the middle estimate sits 1.7-fold (0.22 log units) above what was measured; the range from low to high includes it.
By their numbers in this assay, from the lowest: compounds 1 and 4 (each within the scatter of the next); then compound 2.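

For the compounds shown here, the exchange of 3-chlorophenyl for 2-bromophenyl on an oxygen on a saturated carbon gives, in this assay, no change at the digits printed from compound 1 to compound 4 (within the scatter), and this is the first pair that differs in one place. Going by these compounds alone, on the core of compound 1, this position therefore accepts a change of both the halogen and its place on the phenyl ring with no shift beyond the scatter, although the single step cannot separate those two parts, which might act alone or offset each other. No measurement available here bears on why the two compounds read alike.

Open, on these data alone, is whether 2-chlorophenyl or 3-bromophenyl would read alike, which would separate the halogen from its place on the ring, and whether a phenyl ring carrying an amine or a carboxylic acid in place of the halogen would hold this level. Also open, as far as these compounds go, is whether a longer chain between the core and the phenoxy end, or the same exchange on the core of compound 2, would leave the read-out where it stands.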